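The source may hold more compounds than are shown below. What is called first, only, known or untested is meant among the compounds shown, and "the series" means these compounds.

Measured compounds:
- compound 1 `COC(=O)c1ccc(NC2=CC(=O)c3ncncc3C2=O)cc1` gives 5800 nM in a functional assay on BXPC-3 cells (Homo sapiens) for cytotoxicity, read by MTT assay, with a stated time of 72 h; a lower number here means a stronger inhibitor, a higher number a weaker inhibitor
- compound 2 `O=C1C(Nc2ccc(OC(F)(F)F)cc2)=CC(=O)c2ncncc21` gives 900 nM in this assay
- compound 3 `O=C1C(Nc2ccc(CO)cc2)=CC(=O)c2ncncc21` gives 5700 nM in this assay

Among the measured compounds shown here, compound 3 stands second highest of the three numbers; its nearest neighbour is compound 1, with a 1.0-fold lower number from compound 1 to compound 3 (0.01 log units; within the scatter), and the only step beyond the scatter in this small set is a 6.3-fold higher number from compound 2 to compound 3 (0.80 log units; beyond the scatter) (seen the other way as a 6.4-fold lower number from compound 1 to compound 2 (0.81 log units; beyond the scatter)).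

Compound 4 `NS(=O)(=O)c1ccc(NC2=CC(=O)c3ncncc3C2=O)cc1` differs from compound 3 by sulfamoyl in place of hydroxymethyl on an aromatic carbon. For the measured compounds named here, no measured step swaps a substituent at this position for sulfamoyl, so none bears on it directly. What the series does show is that two of the three groups tried there, methoxycarbonyl and hydroxymethyl, give numbers that sit on top of each other, while only trifluoromethoxy moves this assay by a modest amount. Absent any precedent for sulfamoyl, the expectation is a step of about a 1.1-fold lower number from compound 3 to compound 4 (0.06 log units; within the scatter), that is no change beyond the scatter. Compound 4 is accordingly estimated at 5000 nM, with a range from 1500 nM to 16000 nM.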

Compound 4, half-maximal inhibitory concentration: > 10000 nM
Compound 4: no number, only a limit; the forecaster's own chance of this, stated with the estimate: 10%; at least 2.0-fold (0.30 log units) between middle value and limit.
By their numbers in this assay, from the lowest: compound 2; then compounds 3 and 1 (each within the scatter of the next). At a limit, above all of these: compound 4.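

Compound 4 carries no number in this assay, only a limit: the limit of > 10000 nM in this assay, at which 1 of the 4 values shown sits. Sulfamoyl is the one group at this position shown without a measured number, and the step that reads beyond the scatter is an at least 11-fold higher number from compound 2 to compound 4 (1.04 log units; beyond the scatter). The other two steps are floors within the scatter, an at least 1.7-fold higher number from compound 3 to compound 4 (0.24 log units; that floor lies within the scatter) and an at least 1.7-fold higher number from compound 1 to compound 4 (0.23 log units; that floor lies within the scatter), so they establish no separation from hydroxymethyl or methoxycarbonyl, and trifluoromethoxy remains the only group shown to stand apart from the rest.

As far as these compounds go, how far compound 4 lies past its limit stays open, and with it whether sulfamoyl differs at all from hydroxymethyl or methoxycarbonyl. Also open, from the compounds shown here alone, is how a carboxylic acid or an amine on this aromatic carbon would read against these groups.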